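Replacing hydrogen with bromo in compound 3

A few compounds are considered here, and "the series" means these few. Any claim that something is new, unique, unknown or untested is made for them only; others in the source may bear on it.

Measured in a functional assay on A549 cells (Homo sapiens) for inhibition, read by sulforhodamine B assay, with a stated time of 48 h, tested at 50 uM; on this read-out higher numbers stand for more inhibition of growth at the one concentration tested and lower numbers for less inhibition of growth:
- Compound 1 `COc1cc2c(cc1CC=C(C)C)C(=O)C[C@@H](c1ccc(Oc3ccc(F)cc3)cc1)O2` gives 27%
- Compound 2 `COc1cc2c(cc1CC=C(C)C)C(=O)C[C@@H](c1ccc(Oc3ccccc3)cc1)O2` gives 46%

Of these two compounds, compound 2 stands highest at 46%. Compound 3 `COc1cc2c(cc1CC=C(C)C)C(=O)C[C@@H](c1ccc(Oc3ccc(Br)cc3)cc1)O2` departs from it by bromo in place of hydrogen on an aromatic carbon, with bromo in place of hydrogen on an aromatic carbon, para to a large group. Going by the values given here, only one measured step bears on this: a number 19 percentage points higher from compound 1 to compound 2 (beyond the scatter), which exchanges fluoro for hydrogen. Read in reverse, it suggests a fall of similar modest size on adding bromo, although fluoro is not bromo and a single step is thin evidence. The expected change is a number 13 percentage points lower from compound 2 to compound 3 (beyond the scatter). In this assay, compound 3 is estimated at 33%, with an expected range of 15% to 55%.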

Compound 3, percent growth inhibition at one concentration: 72%
Beside the measured number, compound 3's estimate is 39 percentage points below it; measured number outside the range, above it.
By their numbers in this assay, from the lowest: compound 1; then compound 2; then compound 3.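

In this assay, on the aromatic carbon para to a large group, bromo in place of hydrogen gives a number 26 percentage points higher from compound 2 to compound 3 (beyond the scatter), so the two halogens move the number in opposite directions relative to hydrogen. Exchanging one halogen for the other gives a number 45 percentage points higher from compound 1 to compound 3 (beyond the scatter), the only large step among these compounds. No measurement shown here accounts for this difference between fluoro and bromo. On these data alone, what chloro, iodo or a methoxy group would give on this same carbon remains open, so three compounds cannot yet define a trend across substituents.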